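The compounds below may be only part of what the source reports. "The series", "measured", "known", "first", "only" and "open" are said of these compounds alone.

Among the measured compounds shown here, compound 1 `CC(Sc1nc2c(cnn2C)c(=O)n1-c1ccccc1)c1cccc(F)c1` gives 151 nM in an assay on isolated protein for inhibition of aldehyde dehydrogenase 1A1 (Homo sapiens) (on this read-out lower numbers stand for stronger inhibition and higher numbers for weaker inhibition), the lowest of the three numbers measured so far. Compound 2 `Cn1ncc2c(=O)n(-c3ccccc3)c(SCc3cccc(F)c3)cc21` gives 240 nM in this assay, a number that lies within the usual scatter of compound 1, so the two cannot be told apart, while compound 3 `O=c1c2cncn2nc(SCc2cccc(F)c2)n1-c1ccccc1` gives 2200 nM and is clearly weaker than compound 1. Compound 4 `CC(Sc1nc2c(cnn2C)c(=O)n1-c1ccccc1)c1cccc(O)c1` has not yet been measured. For the measured compounds named here, its single difference from compound 1 is hydroxy in place of fluoro on an aromatic carbon. Going by the values given here, no measured pair of compounds shares this kind of change, so there is no direct guide to its effect. A modest weakening is expected, so that the expected step is a 2.0-fold higher number from compound 1 to compound 4 (0.30 log units; within the scatter), close to the edge of the scatter. Compound 4 is estimated at 300 nM in this assay, with a likely range from 100 nM to 1000 nM.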

Compound 4, half-maximal inhibitory concentration: 130 nM
Estimate against measurement, compound 4: 2.3-fold (0.36 log units) above, within the range that was stated.
By their numbers in this assay, from the lowest: compounds 4, 1 and 2 (each within the scatter of the next); then compound 3.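

Replacing fluoro with hydroxy on the aromatic ring gives a 1.2-fold lower number from compound 1 to compound 4 (0.07 log units; within the scatter) in this assay, so this read-out does not separate the two compounds. At this position, then, a hydrogen-bond donor and acceptor enter without a change that can be told from scatter. Nothing measured here explains this result.

From the compounds shown here alone, it remains open whether a methoxy group, which keeps the oxygen but lacks the hydroxy hydrogen, would also match compound 1. An amine or a carboxylic acid at this position is equally untested by the compounds shown.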